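Amino in Place of Nitro on a Vinyl Sulfone

The compounds below may be only part of what the source reports. "The series", "measured", "known", "first", "only" and "open" are said of these compounds alone.

Compound 1, `COc1cc(/C=C/S(=O)(=O)Cc2ccc(OC)c([N+](=O)[O-])c2)cc(OC)c1`: in a functional assay on MCF7 cells (Homo sapiens) for cytotoxicity, read by MTT assay, with a stated time of 72 h (on this read-out higher numbers stand for weaker inhibition of growth and lower numbers for stronger inhibition of growth), compound 1 gives > 30000 nM.
Compound 2, `COc1ccc(CS(=O)(=O)CC(=O)Nc2c(C)cc(C)cc2C)cc1N`: in this assay compound 2 gives > 30000 nM.
Compound 3, `COc1ccc(OC)c(NC(=O)CS(=O)(=O)Cc2ccc(OC)c([N+](=O)[O-])c2)c1`: in this assay compound 3 gives > 30000 nM.

For compound 1 this value is a limit of the assay and not a number. The same holds for compound 2. The same holds for compound 3. Going by the values given here, compound 1 thus stands at the limit of > 30000 nM in this assay, at which 3 of the 3 values shown sit, and no measured step connects it to any other compound. Compound 4, `COc1cc(/C=C/S(=O)(=O)Cc2ccc(OC)c(N)c2)cc(OC)c1`, differs from compound 1 in one place: amino in place of nitro on an aromatic carbon. Among the compounds with values here, with no measured step to draw on, the size of this change cannot be read from the data; a shift towards stronger inhibition of growth beyond the usual scatter is expected, of uncertain size. For compound 4 the estimate is 300 nM, within 30 nM to 10000 nM, which means an expected step of an at least 100-fold lower number from compound 1 to compound 4 (2.00 log units; beyond the scatter).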

Compound 4, concentration for 50% growth inhibition: 490 nM
The estimate for compound 4 lay 1.6-fold (0.21 log units) below the measured number; the range from low to high includes it.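

In this assay, amino in place of nitro on an aromatic carbon, ortho to a methoxy group, brings an at least 61-fold lower number from compound 1 to compound 4 (1.78 log units; beyond the scatter). Compound 1 sits at a limit of the assay, so this step gives only a minimum size. Compound 4 is the one compound shown that carries a number and not a limit: the limit of > 30000 nM in this assay, at which 3 of the 4 values shown sit.

The compounds shown leave open whether the free amino group itself matters or whether other replacements for nitro would serve as well. A hydroxyl, a methylamino or an acetamido group at this position would address that.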